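Methoxycarbonyl for methoxy: estimate for compound 4

This account rests on a few compounds, and the source may have more. Where it says the series, first, only, none or still open, it means among the compounds named here.

Compound 2 `COc1ccc(CO/N=C/c2c(C)nn(C)c2Oc2ccc(Cl)cc2)cc1` gives the highest of the three numbers in a functional assay on MCF7 cells (Homo sapiens) for antiproliferative activity, tested at 1 uM (on this read-out higher numbers stand for more inhibition at the one concentration tested (going by the name of the read-out) and lower numbers for less inhibition), at 37%. Compound 3 `CC(C)c1nn(-c2ccccc2)c(Oc2ccc(Cl)cc2)c1/C=N/OCc1ccc(C(=O)OC(C)(C)C)cc1` gives -4.9% and compound 1 `Cc1nn(-c2ccccc2)c(Oc2ccc(Cl)cc2)c1/C=N/OCc1ccc(C(=O)OC(C)(C)C)cc1` gives -8.4% in this assay, both beyond the scatter below compound 2. Among the measured compounds shown here, the only measured step, a number 3.5 percentage points higher from compound 1 to compound 3 (within the scatter), concerns a different place and does not bear on the present change. Compound 4 `COC(=O)c1ccc(CO/N=C/c2c(C)nn(C)c2Oc2ccc(Cl)cc2)cc1` differs from compound 2 by methoxycarbonyl in place of methoxy on an aromatic carbon. For the measured compounds named here, no measured pair isolates this change; compounds 1 and 3 carry an ester rather than a methoxy but also differ from compound 2 elsewhere, so their low numbers are only a hint. A downward step is expected, a number 19 percentage points lower from compound 2 to compound 4 (beyond the scatter), with wide uncertainty. Compound 4 is estimated at 18%, range -10% to 45%.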

Compound 4, a percentage reported as inhibition, at one concentration (the size of the read-out at that concentration, not a potency): 33.6%
Beside the measured number, compound 4's estimate is 15.6 percentage points below it; low and high end bracket the measured number.
By their numbers in this assay, from the lowest: compounds 1 and 3 (each within the scatter of the next); then compounds 4 and 2 (each within the scatter of the next).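

In this assay, methoxycarbonyl in place of methoxy on an aromatic carbon, para to a large group, gives a number 3.4 percentage points lower from compound 2 to compound 4 (within the scatter). On this core, the inhibition in this assay is therefore level with either group at this place, and a carbonyl at this place does not by itself cost inhibition at the one concentration tested. No available evidence accounts for this outcome. Open, from the compounds shown here alone, is whether a carboxylic acid or an amine at the same place would keep this level of inhibition. Also open, going by these compounds, is how either group would behave with other substituents on the core.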